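Adding 4-chlorophenyl to compound 1

The compounds below may be only part of what the source reports. "The series", "measured", "known", "first", "only" and "open" are said of these compounds alone.

compound 1 `CCCCCCCCc1ccc(OCC(=O)Cn2cnnn2)cc1`: 22%
compound 2 `CCCCCCCCc1ccc(OCC(=O)Cn2nnc(SC)n2)cc1`: < 5% (a limit of the assay)

Going by the values given here, in an ADME assay on S9 fraction from liver (Rattus norvegicus) for metabolic stability, read by LC-MS, using NADPH, with a stated time of 30 min (on this read-out lower numbers stand for a less stable compound and higher numbers for a more stable compound), compound 1 gives 22%, the only true number so far. Compound 2 gives < 5%, which is a limit of the assay and not a number.

Compound 3 `CCCCCCCCc1ccc(OCC(=O)Cn2nnnc2-c2ccc(Cl)cc2)cc1` has not yet been measured. It differs from compound 1 by a single change, 4-chlorophenyl in place of hydrogen on an aromatic carbon.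

Among the compounds with values here, the only measured step that bears on this change is a number at least 17 percentage points lower from compound 1 to compound 2 (beyond the scatter), with 5-(methylsulfanyl)-2H-tetrazol-2-yl in place of 1H-tetrazol-1-yl. It is a different substitution, so it offers only a rough guide, but it points downward. A fall in this assay is therefore expected, and the estimated step is a number 12 percentage points lower from compound 1 to compound 3 (beyond the scatter). For compound 3 the estimate is 10%, with an expected range of 4% to 24%.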

Compound 3, percent of the compound remaining: 45%
Beside the measured number, compound 3's estimate is 35 percentage points below it, and the stated range ends below it.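

In this assay, this result shows that a large group on the aromatic carbon of the five-membered aromatic ring with 4 nitrogen need not lower the read-out: 4-chlorophenyl in place of hydrogen gives a number 23 percentage points higher from compound 1 to compound 3 (beyond the scatter). The earlier pair showed only a fall, and that pair involved a different change, 5-(methylsulfanyl)-2H-tetrazol-2-yl in place of 1H-tetrazol-1-yl, so it said little about this position. Compound 2 stands at a limit of the assay and not at a number, so the size of its fall remains unknown: the limit of < 5% in this assay, at which 1 of the 3 values shown sits.

The compounds shown leave open whether plain phenyl without the chlorine, a methyl group or an amine on this same carbon would give a similar read-out in this assay. They also leave open whether the gain would hold with a shorter chain on the shared core.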